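The source may hold more compounds than are shown below. What is called first, only, known or untested is meant among the compounds shown, and "the series" means these compounds.

Measured compounds in a toxicity assay on THP-1 cells (Homo sapiens) for inhibition; on this read-out higher numbers stand for lower toxicity in this test and lower numbers for higher toxicity in this test:
compound 1, `Cn1c(-c2ccc(Cl)cc2)cnc1NC(=O)c1ccc(F)cc1`, 37000 nM
compound 2, `Cn1c(-c2ccc(Cl)cc2)cnc1NC(=O)c1ncc[nH]1`, 52000 nM
compound 3, `O=C(Nc1ncc(-c2ccccc2)o1)c1ccc(Cl)cc1`, 10000 nM

Within this set compound 1 holds the second highest of the three numbers. Its nearest neighbour is compound 2, and the step of a 1.4-fold higher number from compound 1 to compound 2 (0.15 log units; within the scatter) stays within the scatter. Going by the values given here, compound 3 lies furthest from compound 1, with a number lower by more than the scatter, but compound 3 differs from compound 1 in more than one place, so its value shows only that a lower number occurs elsewhere in the set and not what any single change does.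

Compound 4, `Cn1c(-c2ccccc2)cnc1NC(=O)c1ccc(F)cc1`, is the unmeasured analogue. The change from compound 1 is hydrogen in place of chloro on an aromatic carbon. Among the compounds with values here, no measured step touches this position: the only single-point step in the set, a 1.4-fold higher number from compound 1 to compound 2 (0.15 log units; within the scatter), exchanges the group on the carbonyl carbon and is within the scatter, so it offers no direct guide. With nothing in the data pointing to a large effect of losing the chloro, a small step is expected, without a clear direction. In this assay compound 4 is estimated at 45000 nM, with a range from 18000 nM to 110000 nM. The expected step is a 1.2-fold higher number from compound 1 to compound 4 (0.09 log units; within the scatter).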

Compound 4, half-maximal cytotoxic concentration: > 100000 nM
Compound 4 was reported as a limit (the forecaster's own chance of this, stated with the estimate: 20%); middle value at least 2.2-fold (0.34 log units) away from the limit.
By their numbers in this assay, from the lowest: compound 3; then compounds 1 and 2 (each within the scatter of the next). At a limit, above all of these: compound 4.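

In this assay compound 4 is reported as a limit and not as a number: the limit of > 100000 nM in this assay, at which 1 of the 4 values shown sits.
Going by these compounds alone, the loss of the chloro gives an at least 2.7-fold higher number from compound 1 to compound 4 (0.43 log units; beyond the scatter), the first single-point step in the set to lie beyond the scatter, while a 1.4-fold higher number from compound 1 to compound 2 (0.15 log units; within the scatter), at the group on the carbonyl carbon, stays within it. The position on the aromatic carbon, para to a large group, therefore matters in this assay: going from 4-chlorophenyl to phenyl shifts the result towards lower toxicity in this test, though the full size of the shift cannot be read from a limit.

Only chloro and hydrogen are shown at this position, so it remains open whether a methoxy group, an amine or a carboxylic acid there would read like compound 1 or like compound 4. On these data alone, it is also open whether the same exchange of 4-chlorophenyl for phenyl carries over to compound 2, with its 1H-imidazol-2-yl group on the carbonyl carbon, or to the different core of compound 3.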